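The source may report more compounds than this note shows. Statements on the series, on what has been measured and on what is new or still open speak of the compounds shown alone.

Measured compounds in a physicochemical assay for lipophilicity; on this read-out higher numbers stand for higher lipophilicity and lower numbers for lower lipophilicity:

compound 1, `COc1ccc2[nH]c(-c3ccccc3)c(C3=C(Br)C(=O)NC3=O)c2c1`, 2.48
compound 2, `CCCCc1ccc2[nH]c(-c3ccccc3)c(C3=C(Br)C(=O)NC3=O)c2c1`, 3.74
compound 3, `CCCCc1ccc2[nH]c(-c3ccc(OC)cc3)c(C3=C(Br)C(=O)NC3=O)c2c1`, 3.83

Compound 1 sits lowest of the three; the step of a number 1.26 log units higher from compound 1 to compound 2 (beyond the scatter) is the change methoxy in place of butyl on an aromatic carbon read in the other direction, and it is large. Beyond that, compound 2 and compound 3 differ by methoxy in place of hydrogen on an aromatic carbon, and the step of a number 0.09 log units higher from compound 2 to compound 3 (within the scatter) is small, within the scatter.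

Unmeasured: compound 4, `COc1cccc(-c2[nH]c3ccc(OC)cc3c2C2=C(Br)C(=O)NC2=O)c1`. From compound 1 it differs by methoxy in place of hydrogen on an aromatic carbon. The same change is made from compound 2 to compound 3; among the compounds shown it occurs twice. The surroundings are not identical: in compound 3 the methoxy stands para to a large group, in compound 4 meta to a large group, so this is the same kind of change rather than the same change. The two cores differ as described by methoxy in place of butyl on an aromatic carbon, with methoxy in place of butyl on an aromatic carbon of the fused system.

Beside the measured step of a number 0.09 log units higher from compound 2 to compound 3 (within the scatter), for compound 4 the expected step of a number 0.10 log units higher from compound 1 to compound 4 (within the scatter) is of the same small size, resting on compound 3 and its value 3.83 against compound 2. The expectation for compound 4 in this assay is 2.58, from 2.3 to 2.9.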

Compound 4, partition coefficient: 2.79
Compound 4: the middle estimate sits 0.21 log units below what was measured, within the range that was stated.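

In this assay the core of compound 1 gives a number 0.31 log units higher from compound 1 to compound 4 (beyond the scatter) for phenyl to 3-methoxyphenyl, while the core bearing butyl gives a number 0.09 log units higher from compound 2 to compound 3 (within the scatter) for methoxy in place of hydrogen on an aromatic carbon. This shows that the same kind of change does not carry over at a fixed size in this series: it clears the scatter on one core and stays within it on the other, although each reading rests on a single pair, and the methoxy stands meta to a large group only in compound 4, not in compound 3. It does not show whether the core or the place of the methoxy separates the two readings, and nothing measured here bears on the cause of the difference.

The compounds shown leave open whether phenyl to 3-methoxyphenyl on the core bearing butyl would match the step seen for the core of compound 1, and whether methoxy at the place it holds in compound 3 would do so on that core. They also leave open how this assay would respond to an amine or a carboxylic acid on the same ring, or to a longer chain in place of butyl.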